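Aryl variation on the oxime ether of a cytotoxicity series

A few compounds are considered here, and "the series" means these few. Any claim that something is new, unique, unknown or untested is made for them only; others in the source may bear on it.

compound 1 `Fc1ccc(CO/N=C2/C(c3c[nH]c4ccccc34)=Nc3ccccc32)cc1`: 27000 nM
compound 2 `FC(F)(F)c1ccc(CO/N=C2/C(c3c[nH]c4ccccc34)=Nc3ccccc32)cc1`: 21900 nM

In a functional assay on A549 cells (Homo sapiens) for cytotoxicity, read by MTT assay, with a stated time of 2 days (a lower number here means a stronger inhibitor, a higher number a weaker inhibitor), compound 1 gives 27000 nM and compound 2 gives 21900 nM. Compound 2 has the lowest number of the two, with compound 1 nearest, and the step of a 1.2-fold lower number from compound 1 to compound 2 (0.09 log units; within the scatter) lies within the scatter. Compound 3 `Fc1ccc(CO/N=C2/C(c3c[nH]c4ccccc34)=Nc3ccccc32)c(Cl)c1` differs from compound 2 by 2-chloro-4-fluorophenyl in place of 4-(trifluoromethyl)phenyl on a saturated chain carbon bound to an oxygen on an unsaturated carbon. Among the measured compounds shown here, the single measured step, exchanging one substituent on that ring for another, stayed within the scatter, and no measured step bears on the chloro. For compound 3 the expected step of a 1.1-fold higher number from compound 2 to compound 3 (0.04 log units; within the scatter) therefore stays within the scatter. The estimate for compound 3 in this assay is 24000 nM, within 8000 nM to 70000 nM.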

Compound 3, half-maximal inhibitory concentration: 21400 nM
Beside the measured number, compound 3's estimate is 1.1-fold (0.05 log units) above it; the measured number falls inside the stated range.
By their numbers in this assay, from the lowest: compounds 3, 2 and 1 (each within the scatter of the next).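

Chloro in place of hydrogen on an aromatic carbon, a kind of change the earlier compounds did not include, gives a 1.3-fold lower number from compound 1 to compound 3 (0.10 log units; within the scatter) in this assay. Exchanging the whole aryl group, 2-chloro-4-fluorophenyl in place of 4-(trifluoromethyl)phenyl, gives a 1.0-fold lower number from compound 2 to compound 3 (0.01 log units; within the scatter), so all three aryl groups on the saturated chain carbon read alike. No evidence at hand bears on this result. The compounds shown leave open whether an amine or a carboxylic acid on this ring, or a longer chain before it, would depart from these values.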